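The compounds below may be only part of what the source reports. "The series", "measured", "known", "first", "only" and "open" are said of these compounds alone.

Compound 1, `Nc1ncnc2c1ncn2CC(O)C(=O)OC1CCCCC1`: 100 ug/mL
Compound 2, `CC(C)CCOC(=O)C(O)Cn1cnc2c(N)ncnc21`: 400 ug/mL

Among the measured compounds shown here, of these two compounds, compound 2 shows the higher number in a functional assay on PRK cells (Oryctolagus cuniculus) for cytotoxicity; on this read-out higher numbers stand for lower toxicity in this test and lower numbers for higher toxicity in this test; its only neighbour is compound 1, and the single measured step, a 4.0-fold higher number from compound 1 to compound 2 (0.60 log units; beyond the scatter), separates them. Compound 3, `CCOC(=O)C(O)Cn1cnc2c(N)ncnc21`, has not yet been measured. It differs from compound 2 in one place: hydrogen in place of isopropyl on a saturated chain carbon, two bonds along the chain from an oxygen next to a carbonyl group. For the measured compounds named here, only the step from compound 1 to compound 2 bears on this change, since both changes sit at the oxygen next to a carbonyl group, and in that step the number rose modestly. Compound 3 shortens the chain at the same position further, so a further rise of similar or smaller size is expected, though a result within the scatter of compound 2 would not be surprising. Compound 3 is therefore estimated at 400 ug/mL, with a range from 200 ug/mL to 800 ug/mL, which means an expected step of no change at the digits printed from compound 2 to compound 3 (within the scatter).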

Compound 3, minimum cytotoxic concentration: > 400 ug/mL
Compound 3 was reported as a limit; the forecaster's own chance of this, stated with the estimate: 30%; the middle value lies on the limit itself.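

In this assay compound 3 is reported as > 400 ug/mL, which is a limit of the assay and not a number. Cutting isopentyl back to ethyl gives a number no lower from compound 2 to compound 3 (the limit leaves the size open), so this shortening does not lower the number, and replacing cyclohexyl with ethyl gives an at least 4.0-fold higher number from compound 1 to compound 3 (0.60 log units; beyond the scatter); at this position, a chain as short as ethyl keeps the higher number that isopentyl showed over cyclohexyl. How far compound 3 really lies past compound 2 cannot be read, because the result sits at the limit: the limit of > 400 ug/mL in this assay, at which 1 of the 3 values shown sits.

The compounds shown leave open how a methyl group on this oxygen, a free carboxylic acid or an amine on the chain would read. They also leave open whether the lower number of compound 1 goes with the cyclohexyl ring itself or with its size.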